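Swapping a carbamate for a trifluoromethyl pyrimidine on the shared core

The source may hold more compounds than are shown below. What is called first, only, known or untested is meant among the compounds shown, and "the series" means these compounds.

Measured compounds:
compound 1 `Cc1nccc(N2CCc3nc(C4(C(=O)Nc5ccc(F)cc5)CCC4)ccc32)n1`: 21 nM
compound 2 `O=C(Nc1ccc(F)cc1)C1(c2ccc3c(n2)CCN3c2ccccn2)CCC1`: 10.9 nM
compound 3 `O=C(OC1CC1)N1CCc2nc(C3(C(=O)Nc4ccc(F)cc4)CCC3)ccc21`: 2.7 nM

All three share one core and differ only in the group on a nitrogen on an aromatic ring in a ring. In an assay on HeLa cells for inhibition of Indoleamine 2,3-dioxygenase 1 (Homo sapiens) (on this read-out lower numbers stand for stronger inhibition and higher numbers for weaker inhibition), compound 3 gives the lowest number of the three. Compound 4 `O=C(Nc1ccc(F)cc1)C1(c2ccc3c(n2)CCN3c2ccnc(C(F)(F)F)n2)CCC1` has not yet been tested; it differs from compound 3 in this way: 2-(trifluoromethyl)pyrimidin-4-yl in place of cyclopropyloxycarbonyl on a nitrogen on an aromatic ring in a ring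

Among the measured compounds shown here, two measured steps bear on this change, since both replace an aromatic ring on that nitrogen with the cyclopropyloxycarbonyl group: a 7.8-fold lower number from compound 1 to compound 3 (0.89 log units; beyond the scatter) and a 4.0-fold lower number from compound 2 to compound 3 (0.61 log units; beyond the scatter). Compound 4 moves the other way, back to an aromatic ring, so a step to higher numbers is expected. Between the two aromatic groups the difference was small: a 1.9-fold lower number from compound 1 to compound 2 (0.28 log units; within the scatter). For the measured compounds named here, no measured pair shows what the trifluoromethyl group does in place of methyl, so compound 4 is expected to land near compounds 1 and 2, with the step of a 5.6-fold higher number from compound 3 to compound 4 (0.74 log units; beyond the scatter) estimated for it. Compound 4 is therefore estimated at 15 nM, in a range from 5 nM to 50 nM.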

Compound 4, half-maximal inhibitory concentration: 127 nM
For compound 4 the middle estimate is 8.5-fold (0.93 log units) below the measured one; measured number above the stated range.
By their numbers in this assay, from the lowest: compound 3; then compounds 2 and 1 (each within the scatter of the next); then compound 4.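

In this assay the aromatic groups on this nitrogen prove not to be interchangeable: 2-methylpyrimidin-4-yl and pyridin-2-yl had stayed within the scatter of each other, yet trifluoromethyl in place of methyl gives a 6.0-fold higher number from compound 1 to compound 4 (0.78 log units; beyond the scatter) as a single change. The new group also falls behind pyridin-2-yl, with a 12-fold higher number from compound 2 to compound 4 (1.07 log units; beyond the scatter) on that swap, and leaving cyclopropyloxycarbonyl for it costs a 47-fold higher number from compound 3 to compound 4 (1.67 log units; beyond the scatter) in all, so the price of an aromatic ring here depends strongly on which ring enters. No measurement offered here explains this loss.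

The compounds shown leave open whether a chlorine or an amine in place of the trifluoromethyl on the pyrimidine would stay near compound 1 or drop toward compound 4. They also leave open whether an ethyl or tert-butyl ester of the same carbonyl link would match compound 3.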